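Acyl Group Replaces Allyl on the Phenolic Oxygen

The compounds below may be only part of what the source reports. "The series", "measured", "known", "first", "only" and "open" are said of these compounds alone.

Compound 1 `C=CCOc1cc(/C=C/C(=O)c2ccc(OC)c3c2OC(C)(C)C=C3)ccc1OC` is the starting point. In a functional assay on K562 cells (Homo sapiens) for cytotoxicity, read by MTT assay (a higher number here means a weaker inhibitor, a lower number a stronger inhibitor), compound 1 gives > 10000 nM, which is a limit of the assay and not a number (the limit of > 10000 nM in this assay, at which 1 of the 3 values shown sits). Compound 2 `COc1ccc(/C=C/C(=O)c2ccc(OC)c3c2OC(C)(C)C=C3)cc1OCCO` gives 8750 nM, and compound 3 `COc1ccc(/C=C/C(=O)c2ccc(OC)c3c2OC(C)(C)C=C3)cc1OC(=O)C(C)C` gives 570 nM. The step of an at least 1.1-fold lower number from compound 1 to compound 2 (0.05 log units; that floor lies within the scatter) is within the scatter. By contrast the step of an at least 17-fold lower number from compound 1 to compound 3 (1.24 log units; beyond the scatter) and the step of a 15-fold lower number from compound 2 to compound 3 (1.19 log units; beyond the scatter) are both large, and in each of them a carbonyl enters on the oxygen on an aromatic ring in place of a saturated chain. Compound 4 `COc1ccc(/C=C/C(=O)Oc2cc(/C=C/C(=O)c3ccc(OC)c4c3OC(C)(C)C=C4)ccc2OC)cc1` differs from compound 1 by the following change: (2-(4-methoxyphenyl)ethenyl)carbonyl in place of allyl on an oxygen on an aromatic ring. Here too a carbonyl enters on the oxygen on an aromatic ring, so the two large steps toward compound 3 are the ones that bear on it, and a comparable large downward step seems likely. For compound 4 the expected step is therefore an at least 12-fold lower number from compound 1 to compound 4 (1.09 log units; beyond the scatter). Compound 4 is accordingly estimated at 800 nM, with a range from 200 nM to 3500 nM.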

Compound 4, half-maximal inhibitory concentration: 380 nM
Compound 4: middle estimate off by 2.1-fold (0.32 log units), on the high side, within the range that was stated.
By their numbers in this assay, from the lowest: compounds 4 and 3 (each within the scatter of the next); then compound 2. At a limit, above all of these: compound 1.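

In this assay, a carbonyl on the oxygen on an aromatic ring again comes with a large step, an at least 26-fold lower number from compound 1 to compound 4 (1.42 log units; beyond the scatter), and likewise a 23-fold lower number from compound 2 to compound 4 (1.36 log units; beyond the scatter), this time with a much larger group that brings one six-membered aromatic ring of carbon only. What sits on the carbonyl carbon can thus differ greatly between isopropyl and 2-(4-methoxyphenyl)ethenyl while the values stay within the scatter of each other, a 1.5-fold lower number from compound 3 to compound 4 (0.18 log units; within the scatter). Compound 1 stands at a limit, so the first of these steps is only a floor: the limit of > 10000 nM in this assay, at which 1 of the 4 values shown sits.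

The compounds shown leave open whether a carbonyl carrying an amine or a carboxylic acid would stay at this level. They also leave open whether a longer saturated chain on the same oxygen, without a carbonyl, would reach it.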